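The compounds below may be only part of what the source reports. "The series", "measured", "known", "first", "only" and "open" are said of these compounds alone.

Two members of the series have so far been run in a functional assay on SW-620 cells (Homo sapiens) for inhibition, read by MTT assay, with a stated time of 72 h; on this read-out higher numbers stand for weaker inhibition and lower numbers for stronger inhibition. Compound 1 `CCCCCCc1cn(Cc2cc(=O)oc3cc(O)ccc23)nn1` returned no number in this assay but only a limit, > 100000 nM. Among the compounds with values here, compound 2 `Cc1ccc(S(=O)(=O)NCc2cn(Cc3cc(=O)oc4cc(O)ccc34)nn2)cc1` is the one compound with a measured figure in this assay, 92200 nM, and it therefore stands alone among the values shown. The other entry is the ceiling of the assay, (the limit of > 100000 nM in this assay, at which 1 of the 2 values shown sits). Compound 3 `O=c1cc(Cn2cc(CNS(=O)(=O)c3ccc(F)cc3)nn2)c2ccc(O)cc2o1` has not yet been measured. It differs from compound 2 by a single change, (fluoro in place of methyl on an aromatic carbon), that is, fluoro in place of methyl on an aromatic carbon. Within the data shown here, no step between measured compounds exists to set a scale for such a change, so no shift beyond the scatter is expected in either direction. For compound 3 the estimate in this assay is 95000 nM, with a range from 40000 nM to 200000 nM. This corresponds to an expected step of a 1.0-fold higher number from compound 2 to compound 3 (0.01 log units; within the scatter).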

Compound 3, half-maximal inhibitory concentration: > 100000 nM
Compound 3: a limit, no number; the forecaster's own chance of this, stated with the estimate: 45%; at least 1.0-fold (0.02 log units) between middle value and limit.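

Fluoro in place of methyl gives the series its first step at this position in this assay: an at least 1.0-fold higher number from compound 2 to compound 3 (0.03 log units; that floor lies within the scatter). Going by these compounds, compound 3 gives > 100000 nM, which is a limit and not a number, so the change from 4-methylphenyl to 4-fluorophenyl shows no stronger inhibition, while the true size of the step remains unknown. With this result, most of the series shown rests at the ceiling of the assay: the limit of > 100000 nM in this assay, at which 2 of the 3 values shown sit.

On these data alone, how far the true value of compound 3 lies from this limit remains open. So does whether an amine, a methoxy group or a carboxylic acid in place of the fluoro would bring the number clearly down from the value of compound 2, 92200 nM.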